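The source may report more compounds than this note shows. Statements on the series, on what has been measured and on what is new or still open speak of the compounds shown alone.

Compound 1 `CC1=C(N2CC2)C(=O)C(CCCOC(N)=O)=C(N2CC2)C1=O` gives 5.55 in a functional assay on L1210 cells (Mus musculus), with a stated time of 1 days; on this read-out higher numbers stand for higher potency (the scale is a negative logarithm) and lower numbers for lower potency. Compound 2 `COCCC1=C(N2CC2)C(=O)C(C)=C(N2CC2)C1=O` gives 5.19.

Compound 2 stands lowest of the two, with compound 1 sitting higher by a step beyond the scatter. Compound 3 `CC1=C(N2CC2)C(=O)C(C(C)COC(N)=O)=C(N2CC2)C1=O` arises from compound 2 by a group of 7 heavy atoms (4 carbon, 1 nitrogen, 2 oxygen; no ring) in place of a group of 4 heavy atoms (3 carbon, 1 oxygen; no ring), on a double-bonded ring carbon. Among the measured compounds shown here, the one step that bears on it, a number 0.36 log units lower from compound 1 to compound 2 (beyond the scatter), went the other way when the carbamate was removed, so putting a carbamate back is expected to raise the number in this assay by about the same amount, a number 0.31 log units higher from compound 2 to compound 3 (beyond the scatter). The estimate for compound 3 is therefore 5.5, between 5.1 and 5.9.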

Compound 3, logarithm of the reciprocal of the active concentration, log(1/C): 5.93
Compound 3: middle estimate off by 0.43 log units, on the low side; measured number above the stated range.
By their numbers in this assay, from the lowest: compound 2; then compound 1; then compound 3.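

At this double-bonded ring carbon in this assay, replacing the 2-methoxyethyl group with the carbamate-bearing group gives a number 0.74 log units higher from compound 2 to compound 3 (beyond the scatter) and so a larger rise than the earlier step alone pointed to. The arrangement of atoms in the group also counts here: two groups with the same 7 heavy atoms still differ, giving a number 0.38 log units higher from compound 1 to compound 3 (beyond the scatter) on the same shared core. Nothing measured here explains either step.

As far as these compounds go, whether an amine or a longer chain at this carbon would hold the number stays open. So does whether a simple hydroxyl at the chain end could stand in for the carbamate.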